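Naphthalen-1-yl Replaces 4-Ethylphenyl on a Sulfur

The source may report more compounds than this note shows. Statements on the series, on what has been measured and on what is new or still open speak of the compounds shown alone.

In a functional assay on SMMC-7721 cells (Homo sapiens) for inhibition, read by CCK-8 assay, with a stated time of 72 h, tested at 2 uM (on this read-out higher numbers stand for more inhibition of growth at the one concentration tested and lower numbers for less inhibition of growth), compound 1 `Cc1cc(C)cc(SCc2ccc(/C=C/C(=O)Nc3ccccc3N)cc2)c1` gives 8.61% and compound 2 `CCc1ccc(SCc2ccc(/C=C/C(=O)Nc3ccccc3N)cc2)cc1` gives 13.2%, so these two lie within the usual scatter of each other. Compound 3 `Nc1ccccc1NC(=O)/C=C/c1ccc(CSc2cccc3ccccc23)cc1` has naphthalen-1-yl in place of 4-ethylphenyl on a sulfur. For the measured compounds named here, the one measured swap on that sulfur, a number 4.6 percentage points higher from compound 1 to compound 2 (within the scatter), is a small guide to a larger group, so no shift beyond the scatter is expected. The estimated change is a number 0.8 percentage points higher from compound 2 to compound 3 (within the scatter). In this assay, compound 3 is expected to give 14%, with an estimated range of 4% to 30%.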

Compound 3, percent growth inhibition at one concentration: 3.7%
The estimate for compound 3 lay 10.3 percentage points above the measured number; measured number outside the range, below it.
By their numbers in this assay, from the lowest: compounds 3, 1 and 2 (each within the scatter of the next).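

In this assay, going from one six-membered aromatic ring to two on the sulfur gives no shift that can be told from scatter: the data show a number 9.5 percentage points lower from compound 2 to compound 3 (within the scatter) and also a number 4.9 percentage points lower from compound 1 to compound 3 (within the scatter). So 4-ethylphenyl, 3,5-dimethylphenyl and naphthalen-1-yl cannot be told apart at this single concentration. Nothing measured here offers an explanation for this result.

From the compounds shown here alone, whether a phenyl ring carrying an amine or a carboxylic acid on this sulfur would move the number beyond the scatter remains open. So does how these three compounds would compare at other concentrations.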